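Removing the benzoyl ester on the ring oxygen

The source may hold more compounds than are shown below. What is called first, only, known or untested is meant among the compounds shown, and "the series" means these compounds.

Of the compounds shown here, three sharing one core have been tested in a functional assay on the whole organism (strain Sprague-Dawley) for inhibition, with Rattus norvegicus as the target, with a stated time of 0.5 h, at a dose of 5 mg/kg by the oral route; a lower number here means less inhibition, a higher number more inhibition at the dose given (going by the name of the read-out). Compound 1 `CCCSc1nc(N[C@@H]2C[C@H]2c2ccc(F)c(F)c2)c2nnn([C@@H]3C[C@H](OCCOC(=O)OCC)[C@@H](O)[C@H]3O)c2n1` gives 47.7% in this assay. Compound 2 `CCCSc1nc(N[C@@H]2C[C@H]2c2ccc(F)c(F)c2)c2nnn([C@@H]3C[C@H](OC(=O)C(C)(C)C)[C@@H](O)[C@H]3O)c2n1` is reported in this assay as "not active" (no number reported), without a single number. Compound 3 `CCCSc1nc(N[C@@H]2C[C@H]2c2ccc(F)c(F)c2)c2nnn([C@@H]3C[C@H](OC(=O)c4ccccc4)[C@@H](O)[C@H]3O)c2n1` gives 20.1% in this assay, the lowest of the two numbers recorded; its nearest neighbour is compound 1, and the step of a number 27.6 percentage points lower from compound 1 to compound 3 (beyond the scatter) was beyond the scatter and modest in size, brought about by a group of 8 heavy atoms with one six-membered aromatic ring in place of a group of 8 heavy atoms without a ring, on an oxygen on a saturated carbon.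

Compound 4 `CCCSc1nc(N[C@@H]2C[C@H]2c2ccc(F)c(F)c2)c2nnn([C@@H]3C[C@H](O)[C@@H](O)[C@H]3O)c2n1` differs from compound 3 by hydrogen in place of benzoyl on an oxygen on a saturated carbon. Among the compounds with values here, no measured step matches this change directly; the only related step is the one from compound 1 to compound 3 at the same oxygen, which shows that what sits there can shift the read-out by a modest amount. Because 47.7% for compound 1 stands well above compound 3, an upward step is expected, though its size is uncertain. Compound 4 is therefore estimated at 45%, within 20% to 70%, meaning an expected step of a number 24.9 percentage points higher from compound 3 to compound 4 (beyond the scatter).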

Compound 4, a percentage reported as inhibition, in the whole organism at one dose (the size of the read-out at that dose, not a potency): 45.7%
The estimate for compound 4 lay 0.7 percentage points below the measured number, and the stated range covers the measured number.
By their numbers in this assay, from the lowest: compound 3; then compounds 4 and 1 (each within the scatter of the next).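

In this assay, the free hydroxy group of compound 4 gives this oxygen on a saturated carbon its first reference point, and against it the benzoyl ester stands apart (a number 25.6 percentage points higher from compound 3 to compound 4 (beyond the scatter)). The ring-free group of compound 1 does not stand apart from hydrogen in the same way (a number 2 percentage points lower from compound 1 to compound 4 (within the scatter)), so within these compounds, carrying a group on this oxygen does not in itself go with a lower read-out; what counts is which group sits there, with compound 3 the one numbered case that departs from the free hydroxy. No independent measurement among the data accounts for the gap between the benzoyl ester and the other two compounds.

Compound 2 carries no number, so its steps cannot be read, and the pivaloyl ester cannot be placed against the benzoyl ester or the free hydroxy. On these data alone, whether a small acetyl ester, a plain methyl ether or a longer alkyl chain on this oxygen would sit with compound 3 or with compound 4 remains open.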